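A few compounds are considered here, and "the series" means these few. Any claim that something is new, unique, unknown or untested is made for them only; others in the source may bear on it.

In a functional assay on KB cells (Homo sapiens) for inhibition, read by sulforhodamine B assay (on this read-out higher numbers stand for weaker inhibition of growth and lower numbers for stronger inhibition of growth), compound 1 (`COc1ccc(-c2ccc(-c3ccc(-c4nc5cc(C)ccc5[nH]4)cc3)cc2)cc1OC`) gives 2190 nM and compound 2 (`Oc1cccc2[nH]c(-c3ccc(-c4ccc(-c5ccc(C(F)(F)F)cc5)cc4)cc3)nc12`) gives 4320 nM on the same read-out, so compound 2 stands within the usual scatter of compound 1. Compound 3 (`Cc1ccc2[nH]c(-c3ccc(-c4ccc(-c5ccc(C(F)(F)F)cc5)cc4)cc3)nc2c1`) differs from compound 2 in one place (5-methyl-1H-benzimidazol-2-yl in place of 4-hydroxy-1H-benzimidazol-2-yl on an aromatic carbon) with 5-methyl-1H-benzimidazol-2-yl in place of 4-hydroxy-1H-benzimidazol-2-yl on an aromatic carbon. Since compound 1 with that same group gives 2190 nM in this assay no step beyond the scatter is expected. The expected step of a 1.7-fold lower number from compound 2 to compound 3 (0.24 log units; within the scatter) is small and lies within the scatter. Compound 3 is estimated at 2500 nM with a range from 800 nM to 8000 nM as the likely span.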

Compound 3, concentration for 50% growth inhibition: 41200 nM
Compound 3: the middle estimate sits 16-fold (1.22 log units) below what was measured; measured number outside the range, above it.
By their numbers in this assay, from the lowest: compounds 1 and 2 (each within the scatter of the next); then compound 3.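

In this assay, 5-methyl-1H-benzimidazol-2-yl in place of 4-hydroxy-1H-benzimidazol-2-yl gives a 9.5-fold higher number from compound 2 to compound 3 (0.98 log units; beyond the scatter), so this exchange weakens growth inhibition when 4-(trifluoromethyl)phenyl is present. With 5-methyl-1H-benzimidazol-2-yl held constant, 4-(trifluoromethyl)phenyl in place of 3,4-dimethoxyphenyl gives a 19-fold higher number from compound 1 to compound 3 (1.27 log units; beyond the scatter), so each of the two places alone moves the number beyond the scatter. Nothing given here explains either step. From the compounds shown here alone, it remains open whether the step from compound 2 follows the loss of the hydroxy group or the arrival of the methyl group, and how a methoxy or an amino group would read there.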